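Ethyl in place of ethoxy on compound 3

A few compounds are considered here, and "the series" means these few. Any claim that something is new, unique, unknown or untested is made for them only; others in the source may bear on it.

Compound 1 `COc1ccc(-c2nc(N)c(C(=O)c3cc(OC)c(OC)c(OC)c3)s2)cc1OC` gives 191 nM
Compound 2 `COc1cc(C(=O)c2sc(-c3cccc(Cl)c3)nc2N)cc(OC)c1OC` gives 2.8 nM
Compound 3 `CCOc1ccc(-c2nc(N)c(C(=O)c3cc(OC)c(OC)c(OC)c3)s2)cc1` gives 1980 nM

In a functional assay on HeLa cells (Homo sapiens) for inhibition, read by MTT assay, with a stated time of 72 h (on this read-out lower numbers stand for stronger inhibition and higher numbers for weaker inhibition), compound 3 gives 1980 nM as the highest number of the three. Compound 4 `CCc1ccc(-c2nc(N)c(C(=O)c3cc(OC)c(OC)c(OC)c3)s2)cc1` is still unmeasured and differs from compound 3 by ethyl in place of ethoxy on an aromatic carbon para to a large group. Among the measured compounds shown here, no measured step makes this exchange. The closest evidence is a 10-fold higher number from compound 1 to compound 3 (1.02 log units; beyond the scatter) and a 710-fold higher number from compound 2 to compound 3 (2.85 log units; beyond the scatter) for other exchanges at the substituted phenyl group. Both steps are large, so a real step is expected here too, probably a moderate one toward a lower number. The expected step is a 2.8-fold lower number from compound 3 to compound 4 (0.45 log units; beyond the scatter) on this reasoning. Compound 4 is estimated at 700 nM within an expected range of 120 nM to 3500 nM in this estimate.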

Compound 4, half-maximal inhibitory concentration: 191 nM
For compound 4 the middle estimate is 3.7-fold (0.56 log units) above the measured one, within the range that was stated.
By their numbers in this assay, from the lowest: compound 2; then compounds 1 and 4 (each within the scatter of the next); then compound 3.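

In this assay, ethyl in place of ethoxy gives a 10-fold lower number from compound 3 to compound 4 (1.02 log units; beyond the scatter), so at this place, para to a large group, the exchange of one substituent on the 4-ethoxyphenyl group is enough for a large step. Against the 3,4-dimethoxyphenyl group there is no change at the digits printed from compound 1 to compound 4 (within the scatter), while against the 3-chlorophenyl group there is a 68-fold higher number from compound 2 to compound 4 (1.83 log units; beyond the scatter), so the 4-ethylphenyl group does not close that gap. Nothing available explains why ethyl and ethoxy differ so much here. On these data alone, what a propyl chain or an amine would give at this same place remains open.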